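Chloro for Methyl on an Indole Thiourea Series

A few compounds are considered here, and "the series" means these few. Any claim that something is new, unique, unknown or untested is made for them only; others in the source may bear on it.

Measured compounds:
compound 1 `Oc1ccccc1NC(=S)Nc1ccc2[nH]ccc2c1` gives 14000 nM
compound 2 `S=C(Nc1ccc(Br)cc1)Nc1ccc2[nH]ccc2c1` gives 23000 nM
compound 3 `Cc1ccc(NC(=S)Nc2ccc3[nH]ccc3c2)c(O)c1` gives 24000 nM

Three thioureas built on a shared core have been tested in an ADME assay on cells for inhibition of Amine oxidase [flavin-containing] A (Homo sapiens), read by spectrophotometry; on this read-out higher numbers stand for weaker inhibition and lower numbers for stronger inhibition. Compound 3 gives the highest number of the three, but its nearest neighbour, compound 2, sits within the scatter of it, and so does compound 1; the three values cannot be told apart. Compound 4 `Oc1cc(Cl)ccc1NC(=S)Nc1ccc2[nH]ccc2c1` differs from compound 3 by chloro in place of methyl on an aromatic carbon. Among the measured compounds shown here, only one measured step bears on this change: a 1.7-fold higher number from compound 1 to compound 3 (0.23 log units; within the scatter), a change at the same aromatic carbon that stayed within the scatter. For the measured compounds named here, no measured pair shows a chloro entering anywhere, and compound 2, which carries a bromo on the other ring, gives a number indistinguishable from compound 3. On this footing compound 4 is expected to stay close to compound 3, with a step of a 1.2-fold lower number from compound 3 to compound 4 (0.08 log units; within the scatter) that does not rise beyond the scatter. The estimate for compound 4 in this assay is 20000 nM, within a range from 8000 nM to 50000 nM.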

Compound 4, half-maximal inhibitory concentration: 6300 nM
Compound 4: middle estimate off by 3.2-fold (0.50 log units), on the high side, outside the stated range (below it).
By their numbers in this assay, from the lowest: compound 4; then compounds 1, 2 and 3 (each within the scatter of the next).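

In this assay, this position proved sensitive to the group it carries: chloro in place of methyl gives a step beyond the scatter (a 3.8-fold lower number from compound 3 to compound 4 (0.58 log units; beyond the scatter)), whereas methyl in place of hydrogen on the same carbon had stayed within it (a 1.7-fold higher number from compound 1 to compound 3 (0.23 log units; within the scatter)). Chloro in place of hydrogen also gives a step beyond the scatter (a 2.2-fold lower number from compound 1 to compound 4 (0.35 log units; beyond the scatter)), so on this carbon, meta to a hydroxy group and para to a large group, chloro separates from both hydrogen and methyl, which cannot be told apart from each other. Nothing available accounts for this difference between chloro and methyl.

The compounds shown leave open whether the effect is particular to chloro or would also appear with fluoro, bromo, trifluoromethyl or an amine on this carbon. They also leave open whether chloro would give a similar step if the hydroxy group were replaced by methoxy.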